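The source may hold more compounds than are shown below. What is called first, only, known or untested is meant among the compounds shown, and "the series" means these compounds.

Compound 2 `O=C(CSc1nc(Nc2ccccc2)c2ccccc2n1)Nc1ccc(F)cc1` and compound 1 `COc1cccc(NC(=O)CSc2nc(Nc3ccccc3)c3ccccc3n2)c1` share one core and differ only in the aryl group on the amide nitrogen. In a functional assay on PC-3 cells (Homo sapiens) for inhibition, read by MTT assay, with a stated time of 72 h (on this read-out lower numbers stand for stronger inhibition and higher numbers for weaker inhibition), compound 1 gives 11600 nM, and in this assay compound 2 gives 9560 nM. Compound 2 thus holds the lowest of the two numbers, but the measured step is a 1.2-fold lower number from compound 1 to compound 2 (0.08 log units; within the scatter), so the two compounds cannot be ranked against each other.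

Compound 3 `O=C(CSc1nc(Nc2ccccc2)c2ccccc2n1)Nc1ccc(Cl)cc1Cl` carries the change (2,4-dichlorophenyl in place of 4-fluorophenyl on an amide-type nitrogen). Among the measured compounds shown here, the only measured step touching this position, the one from compound 1 to compound 2, exchanged one aryl group for another and stayed within the scatter. For the measured compounds named here, no measured step covers a dichlorophenyl group, and none puts a second substituent on that ring, so the bearing of the earlier step is indirect: it shows that one aryl swap at this place left the number essentially unchanged.

On that basis, compound 3 is expected to give a step of about a 1.3-fold lower number from compound 2 to compound 3 (0.11 log units; within the scatter), that is, no change beyond the scatter. The estimate for compound 3 in this assay is 7500 nM, with a range from 2500 nM to 22000 nM.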

Compound 3, half-maximal inhibitory concentration: 9110 nM
The estimate for compound 3 lay 1.2-fold (0.08 log units) below the measured number; the range from low to high includes it.
By their numbers in this assay, from the lowest: compounds 3, 2 and 1 (each within the scatter of the next).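

In this assay, putting 2,4-dichlorophenyl in place of 4-fluorophenyl on the amide-type nitrogen gives a 1.0-fold lower number from compound 2 to compound 3 (0.02 log units; within the scatter), and putting it in place of 3-methoxyphenyl gives a 1.3-fold lower number from compound 1 to compound 3 (0.10 log units; within the scatter). Where the earlier pair showed a single aryl swap at this place, there are now three differently substituted phenyl groups that cannot be ranked against one another, and one of them carries two chlorine atoms on the ring rather than a single substituent. Nothing measured here speaks to why the three numbers stay so close.

From the compounds shown here alone, all three compounds keep a substituted phenyl group at this place, so it remains open whether a carboxylic acid or a dimethylamino group on that ring, or a plain alkyl chain in place of the ring on the amide-type nitrogen, would move the number beyond the scatter. The rest of the structure is the same in all three, so the compounds shown also say nothing about how a change elsewhere on the shared core would read in this assay.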